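The compounds below may be only part of what the source reports. "The series", "measured", "known", "first", "only" and "open" are said of these compounds alone.

Measured so far:
Compound 1, `Cc1cc(=O)[nH]c(=O)n1COC(CO)CO`, gives > 100000 nM in a functional assay on MCF7 cells (Homo sapiens) for inhibition, read by MTT assay, with a stated time of 72 h; a higher number here means a weaker inhibitor, a lower number a stronger inhibitor; that figure is a limit of the assay, not a number.
Compound 2, `O=c1ccn(COC(CO)CO)c(=O)[nH]1`, gives > 100000 nM in this assay ; that figure is again a limit.

Compound 1 therefore stands only at a limit: the assay says where its potency is not, and nothing more. Within the data shown here, the one measured step, a step that the two limits leave unreadable from compound 1 to compound 2, involves hydrogen in place of methyl on an aromatic carbon, and its size cannot be read, since (the limit of > 100000 nM in this assay, at which 2 of the 2 values shown sit).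

Compound 3, `Cc1c(I)c(=O)[nH]c(=O)n1COC(CO)CO`, differs from compound 1 by iodo in place of hydrogen on an aromatic carbon. Among the measured compounds shown here, no measured step touches an iodo group, so nothing here speaks for a change of any size in either direction. Compound 3 is expected to give 100000 nM, with a range from 20000 nM to 300000 nM. The step of a number no higher from compound 1 to compound 3 (the limit leaves the size open) is expected to stay unreadable, most likely ending at the same limit.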

Compound 3, half-maximal inhibitory concentration: > 100000 nM
Compound 3 ended at the assay's limit (the forecaster's own chance of this, stated with the estimate: 70%); the middle value sits exactly at the limit.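

No size can be read for the change from compound 1 to compound 3, since both end at a limit and not at a number: the limit of > 100000 nM in this assay, at which 3 of the 3 values shown sit.

The compounds shown leave open whether a methyl or iodo group changes potency at all in this assay.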